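This account rests on a few compounds, and the source may have more. Where it says the series, first, only, none or still open, it means among the compounds named here.

Three compounds measured in an in vitro assay on LLC-PK1 cells for displacement of a labelled ligand from growth hormone secretagogue receptor type 1 (Homo sapiens) (a lower number here means a stronger inhibitor, a higher number a weaker inhibitor), share a common core. Compound 1 `COc1ccc(Cn2c(CCc3c[nH]c4ccccc34)nnc2[C@H](NC(=O)c2ccccn2)c2c[nH]c3ccccc23)c(OC)c1` gives 1.8 nM. Compound 2 `COc1ccc(Cn2c(CCc3ccccc3)nnc2[C@H](NC(=O)c2ccccn2)c2c[nH]c3ccccc23)c(OC)c1` differs from it by phenyl in place of 1H-indol-3-yl on a saturated chain carbon, two bonds along the chain from an aromatic carbon, and compound 2 gives 1.1 nM; the step of a 1.6-fold lower number from compound 1 to compound 2 (0.21 log units; within the scatter). Compound 3 `COc1ccc(Cn2c(CCc3c[nH]c4ccccc34)nnc2[C@H](NC(=O)Cc2ccncc2)c2c[nH]c3ccccc23)cc1` gives 76 nM in this assay, the highest number of the three; how its core differs from that of compound 1 is not broken down here. Compound 4 `COc1ccc(Cn2c(CCc3ccccc3)nnc2[C@H](NC(=O)Cc2ccncc2)c2c[nH]c3ccccc23)cc1` carries, relative to compound 3, the same change that compound 2 carries relative to compound 1, (phenyl in place of 1H-indol-3-yl on a saturated chain carbon, two bonds along the chain from an aromatic carbon). Because the earlier step of a 1.6-fold lower number from compound 1 to compound 2 (0.21 log units; within the scatter) stayed within the scatter, a step of similar size is expected here, a 1.5-fold lower number from compound 3 to compound 4 (0.18 log units; within the scatter). Compound 4 is therefore estimated at 50 nM in this assay, with a likely range from 20 nM to 130 nM.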

Compound 4, half-maximal inhibitory concentration: 270 nM
The estimate for compound 4 lay 5.4-fold (0.73 log units) below the measured number; measured number above the stated range.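

In this assay phenyl in place of 1H-indol-3-yl gave a 3.6-fold higher number from compound 3 to compound 4 (0.55 log units; beyond the scatter) and so did not carry over unchanged from the earlier pair. The same swap behaves differently on the two cores: the same change on two cores in this assay, a 1.6-fold lower number (0.21 log units; within the scatter) from compound 1 to compound 2 and a 3.6-fold higher number (0.55 log units; beyond the scatter) from compound 3 to compound 4, 5.8-fold (0.76 log units) apart, beyond the scatter of two such steps. The near-silent step on the core of compound 1 is therefore no safe guide to the core of compound 3, but two pairs give no general rule for other cores and do not show which part of the cores accounts for the gap.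

Going by these compounds, it remains open whether the same split would appear on a third core. On these data alone, it is also open how a longer chain than phenethyl, or an amine in place of the phenyl, would fare on either core.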